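Fluoro for Chloro: Expected Half-Life of Compound 3

The compounds below may be only part of what the source reports. "The series", "measured", "known", "first", "only" and "open" are said of these compounds alone.

Compound 1 `C=CC(=O)N1CC(NC(=O)Cn2cc(C(=O)N3CCc4cc(Cl)ccc4C3)c3cc(Br)ccc32)C1` was examined in a physicochemical assay for pharmacokinetics, read by LC-MS, in phosphate buffer, at pH 7.4, in the presence of a further agent that is not named here (a higher number here means that the compound lasts longer, a lower number that the compound disappears faster), where compound 1 gives 1.67 h. Its nearest neighbour on the numbers is compound 2 `C=CC(=O)N1CC(NC(=O)Cn2c(C)c(C(=O)N3CCc4c(cccc4OC)C3)c3cc(Cl)ccc32)C1`, and in this assay compound 2 gives 1.67 h, a value level with that of compound 1 at the digits shown and within the scatter. Among the measured compounds shown here, no pair of measured compounds differs in only one place, so the data give no direct step to gauge how a single change on the shared core moves the half-life.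

Compound 3 `C=CC(=O)N1CC(NC(=O)Cn2cc(C(=O)N3CCc4cc(F)ccc4C3)c3cc(Br)ccc32)C1` differs from compound 1 in one place: fluoro in place of chloro on an aromatic carbon. One halogen replaces another at the same aromatic carbon, with no change in ring count, donors, acceptors or charge. For compound 3 a step of no size beyond the scatter is expected in this assay, a 1.0-fold higher number from compound 1 to compound 3 (0.01 log units; within the scatter), since compound 1 gives 1.67 h and the exchange is small. Compound 3 is therefore estimated at 1.7 h, with a range from 0.9 h to 3.3 h.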

Compound 3, half-life: 1.67 h
Compound 3: the middle estimate sits 1.0-fold (0.01 log units) above what was measured, and the stated range covers the measured number.
By their numbers in this assay, from the lowest: compounds 1, 2 and 3 (each within the scatter of the next).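

Among the compounds shown here, compound 3 gives the first step in this set between compounds that differ in one place: in this assay, fluoro in place of chloro on an aromatic carbon leaves no change at the digits printed from compound 1 to compound 3 (within the scatter) as the whole of the change. The earlier compounds shown here could not show this, and the step now indicates that, at this position on the core of compound 1, one of these halogens can stand in for the other with no readable shift in half-life. Nothing available here bears on why the half-life holds across this exchange.

What the compounds leave open is whether the position stays as undemanding for a group that is not a halogen, such as an amine, a carboxylic acid or a longer alkyl chain. They also leave open whether the same exchange of fluoro for chloro would read the same way on a different core.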